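A few compounds are considered here, and "the series" means these few. Any claim that something is new, unique, unknown or untested is made for them only; others in the source may bear on it.

Measured so far in a functional assay on NCI-H23 cells (Homo sapiens) for cytotoxicity, read by sulforhodamine B assay, with a stated time of 48 h; a lower number here means a stronger inhibitor of growth, a higher number a weaker inhibitor of growth:

compound 1 `ClCc1cccc(Cn2cnc3c(Cl)ncnc32)c1`: 1900 nM
compound 2 `ClCc1ccc(Cn2cnc3nc(Cl)nc(Cl)c32)cc1`: 2340 nM
compound 3 `ClCc1cccc(Cn2cnc3c(Cl)nc(Cl)nc32)c1`: 2130 nM

All three numbers sit close together in this assay. Compound 3 and compound 1 share a core and differ in one place, namely (hydrogen in place of chloro on an aromatic carbon); this gave a 1.1-fold lower number from compound 3 to compound 1 (0.05 log units; within the scatter). Compound 2 is built from the same atoms as compound 3, joined differently; the difference between the two cores is not broken down here.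

Compound 4 `ClCc1ccc(Cn2cnc3ncnc(Cl)c32)cc1` has not yet been measured. It arises from compound 2 by the same change, (hydrogen in place of chloro on an aromatic carbon), made at a place described in identical words. Because a 1.1-fold lower number from compound 3 to compound 1 (0.05 log units; within the scatter), the corresponding step is expected to be a 1.1-fold lower number from compound 2 to compound 4 (0.05 log units; within the scatter), an expectation resting on that single earlier example alone. Compound 4 is therefore estimated at 2100 nM, with most repeat measurements expected to fall from 1000 nM to 4500 nM.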

Compound 4, concentration for 50% growth inhibition: 15800 nM
Compound 4: middle estimate off by 7.5-fold (0.88 log units), on the low side, and the stated range ends below it.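

In this assay, putting hydrogen in place of chloro on an aromatic carbon gives a 6.8-fold higher number from compound 2 to compound 4 (0.83 log units; beyond the scatter). Set beside the earlier example, the change does not carry over unaltered from one core to the other: the same change on two cores in this assay, a 1.1-fold lower number (0.05 log units; within the scatter) from compound 3 to compound 1 and a 6.8-fold higher number (0.83 log units; beyond the scatter) from compound 2 to compound 4, 7.6-fold (0.88 log units) apart, beyond the scatter of two such steps. Among the compounds shown here, with only one example on each core, this does not show which difference between the cores lies behind the gap, or how the same change would behave on a further core.

The compounds shown carry only chloro or hydrogen at this place, so the effect of an amine or a methoxy group there remains open. Every compound also keeps its chloromethyl group, so what a plain methyl group or a longer chain would do in its stead is open too.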